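An ethoxycarbonyl added to the phenyl ring of compound 2

The source may hold more compounds than are shown below. What is called first, only, known or untested is meant among the compounds shown, and "the series" means these compounds.

Compound 2 `O=C(CSC(=S)N[C@H]1CCOC1=O)Nc1ccccc1` carries an unsubstituted phenyl on the amide-type nitrogen of the shared core. In a functional assay on SMMC-7721 cells (Homo sapiens) for cytotoxicity, read by MTT assay, with a stated time of 72 h (on this read-out higher numbers stand for weaker inhibition and lower numbers for stronger inhibition), compound 2 gives > 128000 nM, which is a limit of the assay and not a number. Compound 1 `O=C(CSC(=S)N[C@H]1CCOC1=O)Nc1cccc(Cl)c1`, bearing a 3-chlorophenyl, gives > 128000 nM in this assay, again a limit. Compound 3 `O=C(CSC(=S)N[C@H]1CCOC1=O)Nc1ccccc1Cl`, bearing a 2-chlorophenyl, gives 49900 nM; the step from compound 2 to compound 3 is an at least 2.5-fold lower number from compound 2 to compound 3 (0.40 log units; beyond the scatter), the step from compound 1 to compound 3 is an at least 2.5-fold lower number from compound 1 to compound 3 (0.40 log units; beyond the scatter), and the step from compound 1 to compound 2 is a step that the two limits leave unreadable from compound 1 to compound 2. Two of the three values sit at the limit of > 128000 nM in this assay, at which 2 of the 3 values shown sit.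

Compound 4 `CCOC(=O)c1ccc(NC(=O)CSC(=S)N[C@H]2CCOC2=O)cc1` differs from compound 2 by ethoxycarbonyl in place of hydrogen on an aromatic carbon. Going by the values given here, only the step from compound 2 to compound 3 concerns a group entering the phenyl ring, and it was at least modest; the ethoxycarbonyl enters at a different place, and no measured pair tests it. The expected step in this assay is an at least 1.2-fold lower number from compound 2 to compound 4 (0.10 log units; that floor lies within the scatter), small if any. Compound 4 is estimated at 100000 nM, within 30000 nM to 300000 nM, with a fair chance that only a limit is reported.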

Compound 4, half-maximal inhibitory concentration: 64900 nM
Compound 4: middle estimate off by 1.5-fold (0.19 log units), on the high side; the measured number falls inside the stated range.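

In this assay, adding an ethoxycarbonyl para to a large group on the unsubstituted phenyl ring gives an at least 1.9-fold lower number from compound 2 to compound 4 (0.29 log units; that floor lies within the scatter). Going by these compounds alone, this is the first reading at this position of the ring, and the earlier compounds, which carry only chloro as a ring substituent, did not show that a group placed here can give a measured number. The value of compound 2 is a limit and not a number, so the step is known only as a floor and its true size stays unread: the limit of > 128000 nM in this assay, at which 2 of the 4 values shown sit.

The compounds shown leave open whether the ethoxycarbonyl itself matters or whether a chloro, a carboxylic acid or an amine at this position would serve equally. They also leave open how the ethoxycarbonyl would read elsewhere on the ring, and whether a longer chain in its place would change the number.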